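A few compounds are considered here, and "the series" means these few. Any claim that something is new, unique, unknown or untested is made for them only; others in the source may bear on it.

Compound 2 `COc1cc(-c2cc(/C=C/C(=O)c3ccc(Cl)c(Cl)c3)[nH]n2)cc(OC)c1OC` gives 97% in a functional assay on U-251 cells (Homo sapiens) for cytotoxicity, read by sulforhodamine B assay, with a stated time of 48 h, tested at 0.01 uM (a lower number here means a stronger effect, a higher number a weaker effect of the compound at the concentration tested), the lower of the two numbers in hand, with compound 1 `COc1cc(-c2cc(/C=C/C(=O)c3ccc(N)cc3)[nH]n2)cc(OC)c1OC` nearest at 98%, though a number 1 percentage points lower from compound 1 to compound 2 (within the scatter) lies within the scatter. Going by the values given here, compound 3 `COc1ccc(C(=O)/C=C/c2cc(-c3cc(OC)c(OC)c(OC)c3)n[nH]2)cc1OC` has not yet been measured. 3,4-dimethoxyphenyl in place of 3,4-dichlorophenyl on a carbonyl carbon The only measured step at this place on the carbonyl carbon, a number 1 percentage points lower from compound 1 to compound 2 (within the scatter), stayed within the scatter, so the step of a number 2 percentage points lower from compound 2 to compound 3 (within the scatter) is expected to be none beyond the scatter. Compound 3 is accordingly estimated at 95%, within a range from 80% to 100%.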

Compound 3, a percentage reported as activity, at one concentration (the size of the read-out at that concentration, not a potency): 96%
Compound 3: the middle estimate sits 1 percentage points below what was measured; low and high end bracket the measured number.
By their numbers in this assay, from the lowest: compounds 3, 2 and 1 (each within the scatter of the next).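

Replacing 3,4-dichlorophenyl with 3,4-dimethoxyphenyl on the carbonyl carbon (a number 1 percentage points lower from compound 2 to compound 3 (within the scatter)) left the read-out in this assay unchanged, as did replacing 4-aminophenyl with it (a number 2 percentage points lower from compound 1 to compound 3 (within the scatter)). All three groups at this place therefore give numbers within the scatter of one another at this single concentration, now including a group counted with hydrogen-bond acceptors. No supporting measurement accounts for this result. On these data alone, it remains open whether a carboxylic acid or a longer chain at this place would separate from these three. As far as these compounds go, whether the three compounds differ at other concentrations also remains open.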